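The source may hold more compounds than are shown below. What is called first, only, known or untested is meant among the compounds shown, and "the series" means these compounds.

Measured in an ADME assay on L1210/0 cells (Mus musculus) for cytotoxicity, with a stated time of 48 h (on this read-out higher numbers stand for weaker inhibition and lower numbers for stronger inhibition), so far:
- compound 1 `OC[C@H]1C[C@@H](Cn2cnc3c(-c4ccc(Cl)cc4)ncnc32)c2ccccc21` gives 8440 nM
- compound 2 `CC1(C)[C@@H](Cn2cnc3c(Cl)nc(N)nc32)CC[C@@]1(C)CO` gives 50000 nM

Compound 2 holds the higher of the two numbers, and its gap to compound 1 lies beyond the usual scatter. Compound 3 `CC1(C)[C@@H](Cn2cnc3c(O)nc(N)nc32)CC[C@@]1(C)CO` carries hydroxy in place of chloro on an aromatic carbon. Going by the values given here, no measured step covers this swap, so the expectation rests on the single value of compound 2 (50000 nM) and on the structural change. No shift beyond the scatter is expected, and any drift is expected to go towards weaker inhibition. The estimated change is a 1.4-fold higher number from compound 2 to compound 3 (0.15 log units; within the scatter) in this assay. For compound 3 the expected value is 70000 nM, with an estimated range of 25000 nM to 200000 nM.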

Compound 3, half-maximal inhibitory concentration: > 200000 nM
Compound 3 ended at the assay's limit; the forecaster's own chance of this, stated with the estimate: 45%; middle value at least 2.8-fold (0.45 log units) away from the limit.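

In this assay, going by these compounds alone, hydroxy in place of chloro on an aromatic carbon next to the ring nitrogen gives an at least 4.0-fold higher number from compound 2 to compound 3 (0.60 log units; beyond the scatter) and forms the only single-place step so far. Compound 3 gives > 200000 nM as a limit and not a number, so the step has a lower bound but no exact size: the limit of > 200000 nM in this assay, at which 1 of the 3 values shown sits.

Going by these compounds, how far compound 3 lies past this limit stays open. Also open, on these data alone, is where an amine or a methoxy group on this carbon would fall relative to chloro and hydroxy.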